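The compounds below may be only part of what the source reports. "The series", "measured", "known", "first", "only" and "open" are said of these compounds alone.

Working notes on the series.

Compound 1 `Cc1ncnc2c1c(-c1cc3ccccc3o1)cn2[C@@H]1O[C@H](CO)[C@@H](O)[C@H]1O` carries 1-benzofuran-2-yl on the shared core, and compound 2 `Cc1ncnc2c1c(-c1ccoc1)cn2[C@@H]1O[C@H](CO)[C@@H](O)[C@H]1O` carries furan-3-yl on the same core. In a functional assay on HCT-116 cells (Homo sapiens), read by MTT assay, with a stated time of 72 h (on this read-out higher numbers stand for weaker inhibition and lower numbers for stronger inhibition), compound 1 reaches only the limit of > 20000 nM. In this assay compound 2 likewise reaches only the limit of > 20000 nM. The change from compound 2 to compound 1 is 1-benzofuran-2-yl in place of furan-3-yl on an aromatic carbon; the step that the two limits leave unreadable from compound 2 to compound 1 cannot be sized because of the limit of > 20000 nM in this assay, at which 3 of the 3 values shown sit.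

Compound 3 `Cc1nc(N)c2c(-c3ccoc3)cn([C@@H]3O[C@H](CO)[C@@H](O)[C@H]3O)c2n1` carries furan-3-yl on a different core; the difference between the two cores is not broken down here. In this assay compound 3 gives only the limit of > 20000 nM.

Compound 4 `Cc1nc(N)c2c(-c3cc4ccccc4o3)cn([C@@H]3O[C@H](CO)[C@@H](O)[C@H]3O)c2n1` has not been measured. It differs from compound 3 by 1-benzofuran-2-yl in place of furan-3-yl on an aromatic carbon, the same change, at the same place, as from compound 2 to compound 1. Every measured value in this set sits at the limit, so the earlier step gives no readable size to carry over. The expectation is that the step that the limit leaves unreadable from compound 3 to compound 4 stays within the scatter, resting on compound 3 at its limit of > 20000 nM and on the unreadable earlier step that the two limits leave unreadable from compound 2 to compound 1. Compound 4 is therefore expected to return 30000 nM in this assay, with an estimated range from 8000 nM to 100000 nM, and most probably only a limit rather than a number.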

Compound 4, half-maximal inhibitory concentration: 13100 nM
Compound 4: middle estimate off by 2.3-fold (0.36 log units), on the high side; the range from low to high includes it.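

On the second core, 1-benzofuran-2-yl in place of furan-3-yl gives an at least 1.5-fold lower number from compound 3 to compound 4 (0.18 log units; that floor lies within the scatter) in this assay, and compound 4 is the only compound shown with a number rather than a limit. As far as these compounds go, this shows that the change is compatible with a measurable value on this core, but the printed floor does not establish a change beyond the scatter, and the full size of the step remains unknown. Whether the change carries from one core to the other cannot be judged, because the matching step from compound 2 to compound 1 cannot be read and the step on the second core starts from a limit: the limit of > 20000 nM in this assay, at which 3 of the 4 values shown sit.

The compounds shown leave open whether a group other than furan-3-yl or 1-benzofuran-2-yl on this aromatic carbon, such as an amine, a carboxylic acid or a longer alkyl chain, would give a readable value in this assay. They also leave open whether any such group would give a number on the shared core of compound 1 and compound 2, and whether a fully readable step on one core would hold on the other.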